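A few compounds are considered here, and "the series" means these few. Any claim that something is new, unique, unknown or untested is made for them only; others in the source may bear on it.

Compound 1 `Cc1cc(C)c(CN2CCc3c(Cl)cc([C@H](CO)[C@H]4CCOC4)c(Cl)c3C2=O)c(=O)[nH]1` is the starting point. In an ADME assay on microsomes from liver (Homo sapiens) for metabolic stability, read by LC-MS, using NADPH, with stated times of 10 min and 45 min, tested at 1 uM (a lower number here means slower removal, a higher number faster removal of the compound), compound 1 gives 21.3 uL/min, a single number, whereas its two neighbours were run more than once: compound 2 `Cc1cc(C)c(CN2CCc3c(Cl)cc(C(CO)c4ccon4)c(Cl)c3C2=O)c(=O)[nH]1` gives 22.7 uL/min; 21.2 uL/min (2 entries), and compound 3 `COC(c1cc(Cl)c2c(c1Cl)C(=O)N(Cc1c(C)cc(C)[nH]c1=O)CC2)C1CCN(C(=O)CO)CC1` gives 23 uL/min; 42 uL/min (2 entries). The repeats of compound 2 the several entries of compound 2 in this assay, 22.7 uL/min; 21.2 uL/min (2 entries) lie close together, while those of compound 3 the several entries of compound 3 in this assay, 23 uL/min; 42 uL/min (2 entries) spread further apart, so compound 1 stands in the same general region as both. Compound 4 `Cc1cc(C)c(CN2CCc3c(Cl)cc([C@H](C)CO)c(Cl)c3C2=O)c(=O)[nH]1` has not yet been measured; it differs from compound 1 by a group of 4 heavy atoms (3 carbon, 1 oxygen; no ring) in place of a group of 8 heavy atoms (6 carbon, 2 oxygen; one five-membered non-aromatic ring with 1 hetero atom), on an aromatic carbon. Among the measured compounds shown here, no measured pair mirrors this change, so the step expected in this assay is a 1.2-fold lower number from compound 1 to compound 4 (0.07 log units; within the scatter), which stays within the scatter. Compound 4 is therefore expected to give 18 uL/min, between 9 uL/min and 36 uL/min.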

Compound 4, intrinsic clearance in a liver preparation (reported as CLH), per the amount of preparation that the assay uses: 15.8 uL/min
The estimate for compound 4 lay 1.1-fold (0.06 log units) above the measured number; low and high end bracket the measured number.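

In this assay, putting 1-(hydroxymethyl)ethyl on this aromatic carbon in place of the larger group with its five-membered ring gives a 1.3-fold lower number from compound 1 to compound 4 (0.13 log units; within the scatter). Among the compounds shown here, this is the first step here that changes only one place, and it shows that the ring can leave this position without a readable shift in the number. Repeat entries of a single compound can spread at least as far: the several entries of compound 3 in this assay, 23 uL/min; 42 uL/min (2 entries)

Going by these compounds, whether an amine, a carboxylic acid or a longer chain on this carbon would move the number beyond the scatter stays open.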